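The source may hold more compounds than are shown below. What is called first, only, known or untested is meant among the compounds shown, and "the series" means these compounds.

In a physicochemical assay for solubility, read by HPLC, at pH 7.4 (a higher number here means a more soluble compound, a lower number a less soluble compound), compound 2 `CCN(CC)CCNC(=O)c1ccc(C(CC)(CC)c2ccc(OCSC)c(C)c2)n1CC` gives 74.6 ug/mL and compound 1 `CCN(CC)CCNC(=O)c1ccc(C(CC)(CC)c2ccc(OCS(=O)(=O)c3ccccc3)c(C)c2)n1CC` gives 117 ug/mL. These two values lie within the scatter of each other, so compound 2 has no clear standing apart from compound 1. Next in view is compound 3 `CCN(CC)CCNC(=O)c1ccc(C(CC)(CC)c2ccc(OCSc3ccccc3)c(C)c2)n1CC`, which has not yet been measured: phenyl in place of methyl on a sulfur. In words, this is phenyl in place of methyl on a sulfur, turning methylsulfanyl into phenylsulfanyl.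

For the measured compounds named here, one measured step bears on this change: a 1.6-fold lower number from compound 1 to compound 2 (0.20 log units; within the scatter). Going by the values given here, it is only a partial guide, since methylsulfanyl replaces phenylsulfonyl there, and no measured pair isolates phenyl against methyl on a sulfur. Resting on that single step, a 1.6-fold lower number from compound 1 to compound 2 (0.20 log units; within the scatter), no step beyond the scatter is expected in this assay, and the direction remains open. The expected change is a 1.2-fold lower number from compound 2 to compound 3 (0.09 log units; within the scatter). For compound 3 the estimated value is 60 ug/mL, with an expected range of 25 ug/mL to 125 ug/mL.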

Compound 3, solubility: 25.6 ug/mL
Compound 3: middle estimate off by 2.3-fold (0.37 log units), on the high side, within the range that was stated.
By their numbers in this assay, from the lowest: compound 3; then compounds 2 and 1 (each within the scatter of the next).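

In this assay, the group on the sulfur now matters: phenyl in place of methyl gives a 2.9-fold lower number from compound 2 to compound 3 (0.46 log units; beyond the scatter), a step beyond the scatter that the earlier pair could not show. With phenyl held on the sulfur, the change from phenylsulfonyl to phenylsulfanyl also goes beyond the scatter, at a 4.6-fold lower number from compound 1 to compound 3 (0.66 log units; beyond the scatter), whereas the earlier 1.6-fold lower number from compound 1 to compound 2 (0.20 log units; within the scatter), which changed both the sulfur's substituent and its sulfonyl state in one step, stayed within it. The phenylsulfanyl group of compound 3 therefore stands apart from both the methylsulfanyl and the phenylsulfonyl groups at this place, and no measurement at hand gives a cause for either step.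

The compounds shown leave open whether the sulfonyl-to-sulfanyl step keeps its size with a small group on the sulfur, which methylsulfonyl at this place would test against compound 2. They also leave open whether the step from methyl to phenyl depends on the ring itself or on size alone, a question that a longer chain such as butyl on the sulfur, or a pyridyl ring carrying a ring nitrogen, would bear on.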